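The source may hold more compounds than are shown below. What is called first, only, known or untested is meant among the compounds shown, and "the series" means these compounds.

Within the data shown here, in an assay for positive allosteric modulation of metabotropic glutamate receptor 2 (Rattus norvegicus) (a higher number here means that more compound is needed for the effect, a lower number that less compound is needed), compound 3 `Cc1c(OC[C@@H](C)COc2ccc(Cl)c(C(=O)O)c2)ccc(C(=O)CC(C)(C)C)c1O` gives 377 nM, the second highest of the three numbers measured so far. Compound 2 `Cc1c(OC[C@@H](C)Oc2ccc(F)c(C(=O)O)c2)ccc(C(=O)CC(C)(C)C)c1O` gives 112 nM, a clearly lower number, while compound 1 `Cc1c(OCCCCOc2ccc(F)c(C(=O)N(C)C)c2)ccc(C(=O)CC(C)(C)C)c1O` gives 3810 nM, a clearly higher one. Compound 4 `Cc1cc(C(=O)O)ccc1OC[C@H](C)COc1ccc(C(=O)CC(C)(C)C)c(O)c1C` has not yet been measured. It differs from compound 3 in a single place: 4-carboxy-2-methylphenyl in place of 3-carboxy-4-chlorophenyl on an oxygen on a saturated carbon. Among the measured compounds shown here, no step between two measured compounds is available to guide this, and the change rebuilds the very ring whose acid is replaced by an amide in compound 1, which gives 3810 nM. A modest rise in the number, a little beyond the scatter, is expected: a 1.5-fold higher number from compound 3 to compound 4 (0.16 log units; within the scatter). Compound 4 is therefore estimated at 550 nM, with a range from 150 nM to 2000 nM.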

Compound 4, half-maximal effective concentration: 446 nM
The estimate for compound 4 lay 1.2-fold (0.09 log units) above the measured number, and the stated range covers the measured number.
By their numbers in this assay, from the lowest: compound 2; then compounds 3 and 4 (each within the scatter of the next); then compound 1.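

Putting 4-carboxy-2-methylphenyl in place of 3-carboxy-4-chlorophenyl on an oxygen on a saturated carbon gives a 1.2-fold higher number from compound 3 to compound 4 (0.07 log units; within the scatter) in this assay and so leaves the number unchanged in practical terms. In this pair, the chlorine can go, a methyl can come in and the carboxylic acid can sit at another ring position without a step beyond the scatter. Nothing on hand explains why the two rings read alike. Still open, on these data alone, is whether other groups on this ring, such as a tetrazole in place of the carboxylic acid or an amine in place of the methyl, would keep the number at this level.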